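Cytotoxicity on Vero cells: nitroimidazooxazine series, methoxy variation

The source may hold more compounds than are shown below. What is called first, only, known or untested is meant among the compounds shown, and "the series" means these compounds.

Compound 1 `O=[N+]([O-])c1cn2c(n1)OC[C@@H](OCc1csc(-c3ccc(F)cc3)n1)C2`, compound 2 `COc1ccc(-c2nc(CO[C@@H]3COc4nc([N+](=O)[O-])cn4C3)cs2)cc1F` and compound 3 `Cn1c(CO[C@@H]2COc3nc([N+](=O)[O-])cn3C2)cnc1-c1ccc(F)cc1` share the nitroimidazooxazine core and differ in the five-membered ring attached through the ether linker. In an ADME assay on Vero cells (Chlorocebus sabaeus) for cytotoxicity, with a stated time of 72 h (a lower number here means a stronger inhibitor, a higher number a weaker inhibitor), compound 1 gives > 128000 nM, which is a limit of the assay and not a number. Compound 2 gives > 128000 nM in this assay, again only a limit. Compound 3 gives > 128000 nM in this assay, also a limit. The change from compound 1 to compound 2 is 3-fluoro-4-methoxyphenyl in place of 4-fluorophenyl on an aromatic carbon; the step it made is a step that the two limits leave unreadable from compound 1 to compound 2, unreadable because of the limit of > 128000 nM in this assay, at which 3 of the 3 values shown sit. How the core of compound 3 differs from that of compound 1 is not broken down here.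

Compound 4 `COc1ccc(-c2ncc(CO[C@@H]3COc4nc([N+](=O)[O-])cn4C3)n2C)cc1F` is not yet measured. It carries the same kind of change as compound 2 does, namely (3-fluoro-4-methoxyphenyl in place of 4-fluorophenyl on an aromatic carbon), the place differing in that it sits on a ring with 2 nitrogen, between two ring nitrogen atoms and next to the ring atom that bears a methyl group rather than next to the ring nitrogen and the ring sulfur. Going by the values given here, since the three values so far sit at the limit (the limit of > 128000 nM in this assay, at which 3 of the 3 values shown sit), compound 4 is expected to stay at that limit too, with an expected step that the limit leaves unreadable from compound 3 to compound 4 in this assay. The estimate for compound 4 is 200000 nM, with 128000 nM to 600000 nM as the expected range.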

Compound 4, half-maximal inhibitory concentration: > 128000 nM
Compound 4 was reported as a limit; the forecaster's own chance of this, stated with the estimate: 85%; the middle value does not contradict the limit.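

In this assay compound 4 gives > 128000 nM, a limit of the assay and not a number. No step can be read from compound 3 to compound 4, or from compound 1 to compound 2: the limit of > 128000 nM in this assay, at which 4 of the 4 values shown sit.

The compounds shown leave open whether 3-fluoro-4-methoxyphenyl in place of 4-fluorophenyl alters the read-out at all, and how far any compound lies beyond the limit.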